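This account rests on a few compounds, and the source may have more. Where it says the series, first, only, none or still open, it means among the compounds named here.

In an assay on cells (Endothelial cell) for binding affinity to Endothelin-1 receptor (Sus scrofa) (a higher number here means a weaker inhibitor, a lower number a stronger inhibitor), compound 1 `CSc1cnc(OCCOc2ncnc(NS(=O)(=O)c3ccc(C(C)(C)C)cc3)c2-c2ccc(C(C)C)cc2)nc1` gives 1.2 nM and compound 2 `CSc1cnc(OCCOc2ncnc(NS(=O)(=O)c3ccc(C(C)(C)C)cc3)c2-c2ccc(C(F)(F)F)cc2)nc1` gives 0.0017 nM, so that a 710-fold lower number from compound 1 to compound 2 (2.85 log units; beyond the scatter). Compound 3 `COc1ccc(-c2c(NS(=O)(=O)c3ccc(C(C)(C)C)cc3)ncnc2OCCOc2ncc(SC)cn2)cc1` reaches only a limit of the assay, < 0.001 nM. This places compound 3 at the limit of < 0.001 nM in this assay, at which 1 of the 3 values shown sits; the measured steps show an at least 1200-fold lower number from compound 1 to compound 3 (3.07 log units; beyond the scatter) and an at least 1.7-fold lower number from compound 2 to compound 3 (0.23 log units; that floor lies within the scatter). Compound 4 `CSc1cnc(OCCOc2ncnc(NS(=O)(=O)c3ccc(C(C)(C)C)cc3)c2-c2ccc(C)s2)nc1` differs from compound 3 by 5-methylthiophen-2-yl in place of 4-methoxyphenyl on an aromatic carbon. Among the measured compounds shown here, none of the measured steps exchanges the whole aromatic group; the two steps from compound 1 were large, while the step from compound 2 to compound 3 stays within the scatter, so the coming step is uncertain, with a higher number the more probable outcome. Compound 4 is therefore expected to show an at least 10-fold higher number from compound 3 to compound 4 (1.00 log units; beyond the scatter), an estimated 0.01 nM with a range from 0.0005 nM to 0.5 nM.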

Compound 4, half-maximal inhibitory concentration: 0.16 nM
Beside the measured number, compound 4's estimate is 16-fold (1.20 log units) below it; the range from low to high includes it.
By their numbers in this assay, from the lowest: compound 2; then compound 4; then compound 1. At a limit, below all of these: compound 3.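

At this position, 5-methylthiophen-2-yl is the first group shown that is not a substituted phenyl: it gives an at least 160-fold higher number from compound 3 to compound 4 (2.20 log units; beyond the scatter) and a 94-fold higher number from compound 2 to compound 4 (1.97 log units; beyond the scatter), yet also a 7.5-fold lower number from compound 1 to compound 4 (0.88 log units; beyond the scatter). Leaving the six-membered aromatic ring therefore does not alone set the value, as 4-isopropylphenyl gives a higher number than this five-membered ring. The first of these steps is only a floor, as compound 3 stands at a limit of the assay: the limit of < 0.001 nM in this assay, at which 1 of the 4 values shown sits.

The compounds shown leave open whether the ring, its sulfur or its methyl accounts for the difference from compound 2. An unsubstituted thiophene or a methylfuran at this position could separate these parts.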